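Isopropoxy to Bromo: Effect on Cell Toxicity

A few compounds are considered here, and "the series" means these few. Any claim that something is new, unique, unknown or untested is made for them only; others in the source may bear on it.

Of the compounds shown here, three built on a shared core have been tested in an ADME assay on L6 cells (Rattus norvegicus) for cytotoxicity, read by resazurin assay, with a stated time of 72 h; a higher number here means a weaker inhibitor, a lower number a stronger inhibitor. Compound 1, `CC(C)Oc1ccccc1C(O)(c1ccc(Cl)cc1)c1cccnc1`, gives 48300 nM in this assay. Compound 2, `CC(C)Oc1ccc(C(O)(c2ccc(C(F)(F)F)cc2)c2cccnc2)cc1`, gives 47600 nM. Compound 3, `OC(c1ccc(Cl)cc1)(c1cccnc1)c1ccccc1Br`, gives 55200 nM. These three numbers sit within the usual scatter of one another, so no ranking among them can be drawn.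

Compound 1 and compound 3 differ in a single place: bromo in place of isopropoxy on an aromatic carbon. That exchange produced a 1.1-fold higher number from compound 1 to compound 3 (0.06 log units; within the scatter).

Compound 4, `OC(c1ccc(Br)cc1)(c1ccc(C(F)(F)F)cc1)c1cccnc1`, is not yet measured. It stands to compound 2 as compound 3 stands to compound 1: bromo in place of isopropoxy on an aromatic carbon. The surroundings are not identical, however: in compound 1 the exchanged group is ortho to a large group, whereas in compound 2 it is para to a large group, so this is the same kind of change rather than the very same change. How the core of compound 2 differs from the core of compound 1 is not broken down here.

The step from compound 2 to compound 4 is expected to be a 1.1-fold higher number from compound 2 to compound 4 (0.04 log units; within the scatter), a near-flat move, because a 1.1-fold higher number from compound 1 to compound 3 (0.06 log units; within the scatter) and because compound 2 starts from 47600 nM. Compound 4 is therefore estimated at 52000 nM, with a likely range from 28000 nM to 95000 nM.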

Compound 4, half-maximal inhibitory concentration: 54700 nM
Compound 4: middle estimate off by 1.1-fold (0.02 log units), on the low side; low and high end bracket the measured number.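

In this assay, putting bromo in place of isopropoxy on the core of compound 2 gives a 1.1-fold higher number from compound 2 to compound 4 (0.06 log units; within the scatter), so this exchange is a near-flat move on this core as well. Set side by side, the two exchanges agree: the same change on two cores in this assay, a 1.1-fold higher number (0.06 log units; within the scatter) from compound 1 to compound 3 and a 1.1-fold higher number (0.06 log units; within the scatter) from compound 2 to compound 4, 1.0-fold (0.00 log units) apart, within the scatter of two such steps This shows that, across these two pairs, the change carries from one core to the other with no difference that can be told apart from ordinary repeat-to-repeat variation, yet it does not show that bromo and isopropoxy are interchangeable across the series, nor does it explain why neither step moves the number, since two flat steps on two cores give no information about the cause.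

The compounds shown leave open whether any other group in this place, such as an amine, a carboxylic acid or a longer chain, would move the number beyond the scatter. They also leave open whether the exchange of isopropoxy for bromo would stay this flat on a core that differs more widely from the two seen here.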